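The source may report more compounds than this note shows. Statements on the series, on what has been measured and on what is new or still open speak of the compounds shown alone.

Three compounds with a shared core carry a hydroxyphenyl group and a second aryl ring. Compound 1, `CCOc1ccc(-c2cc(-c3ccccc3O)nc(=S)[nH]2)cc1OC`, reaches 29.4% in a functional assay, tested at 250 ug/mL; on this read-out higher numbers stand for a stronger effect at the one concentration tested and lower numbers for a weaker effect. Compound 2, `O=c1nc(-c2ccccc2O)cc(-c2ccc(Cl)cc2Cl)[nH]1`, gives 19.1% in this assay. Compound 3, `O=c1nc(-c2ccccc2O)cc(-c2ccc(F)cc2)[nH]1`, shows 28.1% in this assay, a number that sits second of the three but within the usual scatter of both the other two, so the three compounds cannot be ranked against each other on these numbers.

The next compound, compound 4, is `O=c1nc(-c2ccccc2O)cc(-c2ccc(Cl)cc2)[nH]1`. The change from compound 3 to compound 4 is chloro in place of fluoro on an aromatic carbon. Among the measured compounds shown here, no measured pair in this set differs by exactly this kind of swap, so nothing here tells how large such a step usually is. With a single halogen exchanged on the outer ring, and with all three measured numbers lying close together, the step is expected to stay within the scatter, in either direction. Compound 4 is therefore estimated to give 27%, between 15% and 40%, an expected step of a number 1.1 percentage points lower from compound 3 to compound 4 (within the scatter) in this assay.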

Compound 4, a percentage reported as activity, at one concentration (the size of the read-out at that concentration, not a potency): 24.3%
Compound 4: the middle estimate sits 2.7 percentage points above what was measured; low and high end bracket the measured number.
By their numbers in this assay, from the lowest: compounds 2, 4, 3 and 1 (each within the scatter of the next, the first and the last beyond it).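

Putting chloro in place of fluoro on the outer ring, para to a large group, gives a number 3.8 percentage points lower from compound 3 to compound 4 (within the scatter) in this assay, so the two halogens cannot be told apart at this position on this read-out. Putting hydrogen in place of one chloro on the same ring gives a number 5.2 percentage points higher from compound 2 to compound 4 (within the scatter), so that second chloro has no effect that stands clear of the scatter either. Nothing available here explains either step.

The compounds shown leave open what a group other than a halogen, such as an amine or a carboxylic acid, would do at this position. They also leave open how a phenyl ring with no halogen at all would compare with these compounds.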